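The compounds below may be only part of what the source reports. "The series", "measured", "known", "first", "only" and "open" are said of these compounds alone.

Going by the values given here, compound 3 `CCN(CC)c1ccc2cc(C(=O)c3ccc(N4CCN(C(=O)CN5CCN(S(=O)(=O)c6ccc(F)cc6)CC5)CC4)cc3)oc2c1` stands at the low end of the three numbers so far in a functional assay on HeLa cells (Homo sapiens) for cytotoxicity, read by MTT assay, with a stated time of 48 h (on this read-out lower numbers stand for stronger inhibition and higher numbers for weaker inhibition), though its gaps to both neighbours fall within the scatter. In this assay compound 3 gives 16700 nM. Compound 1 `CCN(CC)c1ccc2cc(C(=O)c3ccc(N4CCN(C(=O)CN5CCN(S(=O)(=O)C6CC6)CC5)CC4)cc3)oc2c1` gives 28100 nM. Compound 2 `CCN(CC)c1ccc2cc(C(=O)c3ccc(N4CCN(C(=O)CN5CCN(S(=O)(=O)c6ccc(OC(F)(F)F)cc6)CC5)CC4)cc3)oc2c1` gives 30200 nM. The three measured steps, a 1.7-fold lower number from compound 1 to compound 3 (0.23 log units; within the scatter), a 1.8-fold lower number from compound 2 to compound 3 (0.26 log units; within the scatter) and a 1.1-fold higher number from compound 1 to compound 2 (0.03 log units; within the scatter), all concern the group on the sulfonyl sulfur and none of them moves beyond the scatter. Compound 4 `CCOC(=O)CN1CCN(CC(=O)N2CCN(c3ccc(C(=O)c4cc5ccc(N(CC)CC)cc5o4)cc3)CC2)CC1` differs from compound 3 in a different way: (ethoxycarbonyl)methyl in place of (4-fluorophenyl)sulfonyl on an amine nitrogen in a ring. Among the compounds with values here, no measured step removes the sulfonyl itself, so the earlier steps bear on this change only indirectly; they show that the shared core has tolerated three different groups at this end of the molecule with numbers that stay close together in this assay. On that basis compound 4 is expected to give a number near that of compound 3, with no step beyond the scatter, about 22000 nM, ranging from 8000 nM to 60000 nM, which corresponds to an expected step of a 1.3-fold higher number from compound 3 to compound 4 (0.12 log units; within the scatter).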

Compound 4, half-maximal inhibitory concentration: 22100 nM
Estimate against measurement, compound 4: 1.0-fold (0.00 log units) below; the range from low to high includes it.
By their numbers in this assay, from the lowest: compounds 3, 4, 1 and 2 (each within the scatter of the next).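

Going by these compounds alone, compound 4 is the first with no sulfonyl on the amine nitrogen in the ring, and the first whose group there has no ring. Even so, in this assay the replacement of (4-fluorophenyl)sulfonyl by (ethoxycarbonyl)methyl gives a 1.3-fold higher number from compound 3 to compound 4 (0.12 log units; within the scatter), and the replacement of cyclopropylsulfonyl by the same group gives a 1.3-fold lower number from compound 1 to compound 4 (0.10 log units; within the scatter), so this position accepts a sulfonyl or an ester-bearing chain with no step beyond the scatter. No measurement here offers an explanation for how closely these numbers agree.

The compounds shown leave open how a free carboxylic acid, an amine or a longer chain at this position would compare with the ethyl ester. Every step here stays within the scatter, and whether any group at this position can move the number beyond it remains unanswered.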